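A few compounds are considered here, and "the series" means these few. Any claim that something is new, unique, unknown or untested is made for them only; others in the source may bear on it.

Compound 1 `CC1CCN(c2c(S(=O)(=O)c3ccc(Cl)c(Cl)c3)cnc3cc(F)ccc23)CC1` gives 94% in an assay on isolated protein for displacement of a labelled ligand from metabotropic glutamate receptor 5 (Homo sapiens), with a stated time of 60 min, tested at 1 uM; a lower number here means less inhibition, a higher number more inhibition at the concentration tested (going by the name of the read-out). Compound 2 `CC1CCN(c2c(S(=O)(=O)c3cccc(Cl)c3)cnc3cc(Cl)ccc23)CC1` gives 92% in this assay, the lowest of the two numbers, though within the scatter of compound 1. Compound 3 `CC1CCN(c2c(S(=O)(=O)c3ccc(Cl)cc3)cnc3cc(Cl)ccc23)CC1` differs from compound 2 by 4-chlorophenyl in place of 3-chlorophenyl on a sulfonyl sulfur. Within the data shown here, no step between measured compounds bears on this change; the comparison between compound 1 and compound 2 shows a chlorine shifted to a different place on the phenyl while the read-out stayed within the scatter. The step from compound 2 to compound 3 is therefore expected to be small, a number 2 percentage points lower from compound 2 to compound 3 (within the scatter), in no certain direction. Compound 3 is estimated at 90%, between 75% and 98%.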

Compound 3, a percentage reported as inhibition, at one concentration (the size of the read-out at that concentration, not a potency): 91%
For compound 3 the middle estimate is 1 percentage points below the measured one; the range from low to high includes it.
By their numbers in this assay, from the lowest: compounds 3, 2 and 1 (each within the scatter of the next).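

In this assay, among these compounds, 4-chlorophenyl in place of 3-chlorophenyl on a sulfonyl sulfur gives a step (a number 1 percentage points lower from compound 2 to compound 3 (within the scatter)), the first reading of this change alone. At this single concentration, the read-out does not separate the two groups, and it is not a measure of potency. No measured property is available to account for this result.

The compounds shown leave open what an unsubstituted phenyl, a methoxyphenyl or a pyridine ring would give on the sulfonyl sulfur. They also leave open whether compound 2 and compound 3 differ in potency.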